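Chloroacetamide to acrylamide on a phenoxyphenyl pyrazole acid

This account rests on a few compounds, and the source may have more. Where it says the series, first, only, none or still open, it means among the compounds named here.

Measured so far:
compound 1, `C=CC(=O)N1CCCC(n2nc(-c3ccc(Oc4ccccc4)cc3)cc2C(=O)OCC)C1`: 13800 nM
compound 2, `O=C(O)c1cc(-c2ccc(Oc3ccccc3)cc2)nn1C1CCCN(C(=O)CCl)C1`: 2200 nM

In a functional assay on Rec1 cells (Homo sapiens) for inhibition, read by luminescence and CellTiter-Glo, with a stated time of 72 h (on this read-out higher numbers stand for weaker inhibition and lower numbers for stronger inhibition), compound 2 gives the lower of the two numbers, and the gap to compound 1 lies beyond the scatter. Going by the values given here, compound 1 and compound 2 differ in more than one place, so no single step is drawn between them. Compound 3, `C=CC(=O)N1CCCC(n2nc(-c3ccc(Oc4ccccc4)cc3)cc2C(=O)O)C1`, is not yet measured. It differs from compound 2 in one place: vinyl in place of chloromethyl on a carbonyl carbon. Nothing measured here isolates this change, so the expected step of a 2.7-fold higher number from compound 2 to compound 3 (0.44 log units; beyond the scatter) is a modest rise toward weaker inhibition, with wide uncertainty. Compound 3 is estimated at 6000 nM, ranging from 2000 nM to 20000 nM.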

Compound 3, half-maximal inhibitory concentration: 50000 nM
Compound 3: middle estimate off by 8.3-fold (0.92 log units), on the low side; the measured number lies above the stated range.
By their numbers in this assay, from the lowest: compound 2; then compound 1; then compound 3.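

In this assay, the group on this carbonyl carbon weighs heavily even though the swap keeps the heavy-atom count: vinyl in place of chloromethyl gives a 23-fold higher number from compound 2 to compound 3 (1.36 log units; beyond the scatter), the larger of the two new steps. With vinyl kept, the ethyl ester also matters, since hydrogen in place of ethyl gives a 3.6-fold higher number from compound 1 to compound 3 (0.56 log units; beyond the scatter), so the acid form is not the better one in this pair. Nothing at hand explains either step. Still open, from the compounds shown here alone, are how chloromethyl reads alongside the ethyl ester, and how a primary amide in place of the acid, or a longer chain in place of vinyl, would read.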